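Rotarod toxicity notes on a benzazepinone amide series

The compounds below may be only part of what the source reports. "The series", "measured", "known", "first", "only" and "open" are said of these compounds alone.

Measured so far:
compound 1 `CC1C(=O)NC(c2ccc(N)cc2)c2ccccc21`: 250 mg/kg
compound 2 `Cc1ccc2c(c1)C(c1ccc(N)cc1)NC(=O)C2(C)C`: 1030 mg/kg
compound 3 `CC(C)NCC(=O)Nc1ccc(C2NC(=O)C(C)(C)c3ccccc32)cc1`: 1600 mg/kg

In a toxicity assay on the whole organism with Mus musculus as the target, in the rotarod test (on this read-out higher numbers stand for an effect only at larger amounts of compound and lower numbers for an effect already at smaller amounts), compound 3 gives 1600 mg/kg, the highest of the three numbers. Compound 2 sits within the scatter of it in this assay, so no order between compounds 2 and 3 can be read; compound 1 lies beyond the scatter below compound 3. Compound 4 `CC1(C)C(=O)NC(c2ccc(NC(=O)CN3CCCCC3)cc2)c2ccccc21` is not yet measured in this assay. Compared with compound 3 it carries piperidin-1-yl in place of isopropylamino on a saturated chain carbon bound to a carbonyl carbon. For the measured compounds named here, no measured pair here shows this change, so there is nothing to anchor the size of the step in this assay. A step no larger than the scatter is expected, in no firm direction, so compound 4 is estimated at 1500 mg/kg, range 700 mg/kg to 3200 mg/kg, which means an expected step of a 1.1-fold lower number from compound 3 to compound 4 (0.03 log units; within the scatter).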

Compound 4, dose for half-maximal effect: > 2000 mg/kg
Compound 4: no number, only a limit; the forecaster's own chance of this, stated with the estimate: 20%; middle value at least 1.3-fold (0.12 log units) from the limit.
By their numbers in this assay, from the lowest: compound 1; then compounds 2 and 3 (each within the scatter of the next). At a limit, above all of these: compound 4.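

In this assay compound 4 gives > 2000 mg/kg, which is a limit of the assay and not a number. Piperidin-1-yl in place of isopropylamino on a saturated chain carbon bound to a carbonyl carbon gives an at least 1.2-fold higher number from compound 3 to compound 4 (0.09 log units; that floor lies within the scatter), so this position takes a six-membered non-aromatic ring with no move to a lower number. The true size of the step stays unread: the limit of > 2000 mg/kg in this assay, at which 1 of the 4 values shown sits.

Still open, going by these compounds, is how morpholin-4-yl or dimethylamino would read at this place. On these data alone, a longer chain carrying the piperidin-1-yl group is equally open.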